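This account rests on a few compounds, and the source may have more. Where it says the series, first, only, none or still open, it means among the compounds named here.

Measured compounds in an ADME assay on L1210/0 cells (Mus musculus) for cytotoxicity, with a stated time of 48 h; a higher number here means a weaker inhibitor, a lower number a stronger inhibitor:
Compound 1, `O=C(/C=C/c1cc(=O)[nH]c(=O)n1COCCO)c1ccccc1`, gives 43300 nM.
Compound 2, `Cc1ccc(C(=O)/C=C/c2cc(=O)[nH]c(=O)n2COCCO)cc1`, gives 27900 nM.
Compound 3, `COc1c(C)c(C)c(OC)c(-c2cn([C@H]3C[C@H](O)[C@@H](CO)O3)c(=O)[nH]c2=O)c1C`, gives only a limit of the assay, > 200000 nM.

Compounds 1 and 2 share one core; the difference between that core and the core of compound 3 is not broken down here. Between compound 2 and compound 1 the change is hydrogen in place of methyl on an aromatic carbon, and it brought a 1.6-fold higher number from compound 2 to compound 1 (0.19 log units; within the scatter). Compound 4, `COc1cc(-c2cn([C@H]3C[C@H](O)[C@@H](CO)O3)c(=O)[nH]c2=O)c(OC)c(C)c1C`, is not yet measured in this assay. It differs from compound 3 by hydrogen in place of methyl on an aromatic carbon, the same kind of change as from compound 2 to compound 1, though the place differs: here the carbon is ortho to a large group, ortho to a methoxy group, meta to a methoxy group, meta to a methyl group and para to a methyl group, whereas in compound 2 it is para to a large group. For compound 3 only the limit of > 200000 nM in this assay, at which 1 of the 3 values shown sits, is known. Because a 1.6-fold higher number from compound 2 to compound 1 (0.19 log units; within the scatter) lies within the scatter, the step expected in this assay is a step that the limit leaves unreadable from compound 3 to compound 4. Compound 4 is therefore estimated at 300000 nM, with a range from 100000 nM to 1000000 nM, and most likely reported as a limit again.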

Compound 4, half-maximal inhibitory concentration: > 200000 nM
Compound 4 was reported as a limit (the forecaster's own chance of this, stated with the estimate: 85%); the middle value is on the limit's open side.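

In this assay compound 3 and compound 4 both stand only as a limit, so no step can be read between them: the limit of > 200000 nM in this assay, at which 2 of the 4 values shown sit.

The compounds shown leave open where compound 3 and compound 4 truly lie relative to that limit, and what hydrogen in place of methyl on an aromatic carbon does to the number on this core.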